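The compounds below may be only part of what the source reports. "The series", "measured", "known", "first", "only" and "open" are said of these compounds alone.

Three compounds share a common core and have been measured in a physicochemical assay for solubility, with a stated time of 18 h, at pH 7.4; on this read-out higher numbers stand for higher solubility and lower numbers for lower solubility:

Compound 1 `c1ccc(Oc2ccc3c(NCCCNCc4ccco4)ccnc3c2)cc1` gives 14500 nM.
Compound 2 `COc1cccc(CNCCCNc2ccnc3cc(Oc4ccccc4)ccc23)c1O` gives 14500 nM.
Compound 3 `COc1cccc(Oc2ccc3c(NCCCNCc4ccco4)ccnc3c2)c1` gives 14500 nM.

Compound 2 stands level with compounds 1 and 3 in this assay; its nearest neighbour by structure is compound 1, and the two steps that link the set, no change at the digits printed from compound 1 to compound 2 (within the scatter) and no change at the digits printed from compound 1 to compound 3 (within the scatter), both lie within the scatter. Neither step touches the aromatic carbon that carries the phenoxy group, so neither bears directly on the change that leads to compound 4 `COc1ccc(-c2ccc3c(NCCCNCc4cccc(OC)c4O)ccnc3c2)cc1`, which has yet to be measured. That change is 4-methoxyphenyl in place of phenoxy on an aromatic carbon. Across the three measured compounds the solubility has not moved, whatever was altered at the chain end or on the distant aromatic ring; nothing here shows what this assay does when the phenoxy group itself is exchanged for 4-methoxyphenyl. On that basis the expectation for compound 4 is a step of about a 1.3-fold lower number from compound 2 to compound 4 (0.12 log units; within the scatter), that is, no change beyond the scatter, but with a range broad enough to allow for an unprobed position. Compound 4 is therefore estimated at 11000 nM, expected to fall between 3500 nM and 25000 nM.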

Compound 4, solubility: 32000 nM
Compound 4: the middle estimate sits 2.9-fold (0.46 log units) below what was measured, and the stated range ends below it.
By their numbers in this assay, from the lowest: compounds 1, 2 and 3 (each within the scatter of the next); then compound 4.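

In this assay, this aromatic carbon of the shared core is the only place among those shown where a change reads beyond the scatter: 4-methoxyphenyl in place of phenoxy gives a 2.2-fold higher number from compound 2 to compound 4 (0.34 log units; beyond the scatter), whereas the two earlier steps, at the chain end and on the phenoxy ring, stayed within it. The step is modest and rests on a single pair, but it shows that a read-out flat at those two other places does respond at this position, and that with this exchange it moves towards higher solubility. Nothing available accounts for the step.

The exchange alters two things at once, removing the oxygen that joined the ring to the core and adding a methoxy group to that ring, and the compounds shown do not separate the two; plain phenyl or 4-methoxyphenoxy on this carbon would. Also open, going by these compounds, are whether the same step holds with furan-2-yl at the chain end, as in compound 1, and how a morpholine or a carboxylic acid on this carbon would read in this assay.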